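The source may hold more compounds than are shown below. What is called first, only, known or untested is meant among the compounds shown, and "the series" means these compounds.

Measured compounds:
compound 1 `CS(=O)(=O)c1cccc(Cn2cc(Cl)cc(C(N)=O)c2=N)c1`: 52 nM
compound 2 `CC(c1cccc(S(C)(=O)=O)c1)n1cc(Cl)cc(C(N)=O)c1=N`: 15 nM

In an assay on CHO-K1 cells for displacement of a labelled ligand from Alpha-1D adrenergic receptor (Homo sapiens), read by scintillation counting, with a stated time of 60 min (a lower number here means a stronger inhibitor, a higher number a weaker inhibitor), compound 1 gives 52 nM, the higher of the two numbers; its nearest neighbour is compound 2, reached by a 3.5-fold lower number from compound 1 to compound 2 (0.54 log units; beyond the scatter). Compound 3 `CS(=O)(=O)c1cc(Cl)cc(Cn2cc(Cl)cc(C(N)=O)c2=N)c1` differs from compound 1 by chloro in place of hydrogen on an aromatic carbon, on an aromatic carbon of the six-membered aromatic ring of carbon only, meta to the methylsulfonyl group. Among the compounds with values here, the single measured step sits on the saturated chain carbon and does not touch that ring, so no measured step bears on this change. The expected step of a 1.2-fold lower number from compound 1 to compound 3 (0.06 log units; within the scatter) is therefore none beyond the scatter. Compound 3 is estimated at 45 nM, range 18 nM to 110 nM.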

Compound 3, inhibition constant: 4.8 nM
Compound 3: middle estimate off by 9.4-fold (0.97 log units), on the high side; the whole stated range lies above it.
By their numbers in this assay, from the lowest: compound 3; then compound 2; then compound 1.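

In this assay the aromatic ring carrying the methylsulfonyl group proves sensitive to substitution: chloro in place of hydrogen on an aromatic carbon, meta to the methylsulfonyl group, gives an 11-fold lower number from compound 1 to compound 3 (1.03 log units; beyond the scatter) and is a large step. Within the data shown here, this is the first measured change on that ring, as the earlier step sat on the saturated chain carbon. No available evidence explains the size of this step.

On these data alone, whether the chloro and the methyl of compound 2 combine in one compound remains open. So does whether fluoro, methoxy or an amine at this place would give a comparable step.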